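A few compounds are considered here, and "the series" means these few. Any claim that something is new, unique, unknown or untested is made for them only; others in the source may bear on it.

Compound 1 `Cn1ccnc1SCC(=O)Nc1ccc(-c2nc(-c3ccccc3)c(-c3ccccc3)n2C)cc1` and compound 2 `Cn1c(-c2ccc(NC(=O)CN3CCN(c4ccccc4)CC3)cc2)nc(-c2ccccc2)c1-c1ccccc1` share one core. In a functional assay on MCF7 cells (Homo sapiens) for cytotoxicity, read by MTT assay, with a stated time of 24 h, tested at 6.4 ug/mL (on this read-out lower numbers stand for a weaker effect and higher numbers for a stronger effect at the one concentration tested), compound 1 gives 27.2%, while compound 2 gives 37.7%, the highest of the two numbers; the move was a number 10.5 percentage points higher from compound 1 to compound 2 (beyond the scatter). Compound 3 `Cn1c(-c2ccc(NC(=O)CN3CCN(Cc4ccc(Cl)cc4)CC3)cc2)nc(-c2ccccc2)c1-c1ccccc1` differs from compound 2 by 4-chlorobenzyl in place of phenyl on an amine nitrogen in a ring. Within the data shown here, no measured step touches that ring nitrogen, and the one known step changed a different part of the chain, so nothing here tells what this change does. The expected step is therefore a number 0.3 percentage points higher from compound 2 to compound 3 (within the scatter), within the scatter. Compound 3 is estimated at 38%, between 20% and 56%.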

Compound 3, a percentage reported as activity, at one concentration (the size of the read-out at that concentration, not a potency): 33.4%
Compound 3: middle estimate off by 4.6 percentage points, on the high side, within the range that was stated.
By their numbers in this assay, from the lowest: compounds 1, 3 and 2 (each within the scatter of the next, the first and the last beyond it).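

Putting 4-chlorobenzyl in place of phenyl on the amine nitrogen in the ring gives a number 4.3 percentage points lower from compound 2 to compound 3 (within the scatter) in this assay and so leaves the two groups indistinguishable on this read-out. Among these compounds, this is the first measured step at this ring nitrogen, since the earlier step changed a different part of the chain. Nothing available explains this result.

Open, going by these compounds, is whether an unsubstituted benzyl, lacking the chlorine, would read the same as these two groups. Also open, on these data alone, is how a small methyl or a bare hydrogen on that nitrogen would read.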